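A few compounds are considered here, and "the series" means these few. Any claim that something is new, unique, unknown or untested is made for them only; others in the source may bear on it.

Three compounds share one core and differ only in the group on an aromatic carbon of the phenyl ring. Compound 1 `O=C(c1ccccc1)c1cccc(NC(=O)C2CCCN(C(=O)c3cc(C(F)(F)F)cc(C(F)(F)F)c3)C2)c1` carries a benzoyl group there and in an ADME assay on PC-3 cells (Homo sapiens) for cytotoxicity, read by WST assay, tested at 100 uM (a higher number here means more inhibition at the concentration tested (going by the name of the read-out), a lower number less inhibition), compound 1 gives 0%. Compound 2 `COC(=O)c1cc(-c2cccc(NC(=O)C3CCCN(C(=O)c4cc(C(F)(F)F)cc(C(F)(F)F)c4)C3)c2)co1` carries a 5-(methoxycarbonyl)furan-3-yl group, and in this assay compound 2 gives 0%. Compound 3 `O=C(Nc1cccc(-c2cnco2)c1)C1CCCN(C(=O)c2cc(C(F)(F)F)cc(C(F)(F)F)c2)C1` carries a 1,3-oxazol-5-yl group, and in this assay compound 3 gives 9%. Compound 3 stands highest of the three numbers, yet its distance to both neighbours is within the scatter, so no order among them can be read.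

Compound 4 `Cc1nc(-c2cccc(NC(=O)C3CCCN(C(=O)c4cc(C(F)(F)F)cc(C(F)(F)F)c4)C3)c2)cs1` is compound 3 with the change (2-methyl-1,3-thiazol-4-yl in place of 1,3-oxazol-5-yl on an aromatic carbon). Within the data shown here, the steps that bear on this exchange are those at the same aromatic carbon: a number 9 percentage points higher from compound 1 to compound 3 (within the scatter), a number 9 percentage points higher from compound 2 to compound 3 (within the scatter) and no change at the digits printed from compound 1 to compound 2 (within the scatter). Among the measured compounds shown here, every exchange of the group at this position so far has left this assay unmoved beyond the scatter, so a step of the same kind is expected here, that is a number 4 percentage points lower from compound 3 to compound 4 (within the scatter). Compound 4 is therefore expected to give about 5% in this assay, with a range from 0% to 20%.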

Compound 4, a percentage reported as inhibition, at one concentration (the size of the read-out at that concentration, not a potency): 1%
Compound 4: the middle estimate sits 4 percentage points above what was measured, and the stated range covers the measured number.
By their numbers in this assay, from the lowest: compounds 1, 2, 4 and 3 (each within the scatter of the next).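

The exchange of 1,3-oxazol-5-yl for 2-methyl-1,3-thiazol-4-yl puts sulfur in place of the ring oxygen and adds a methyl group, yet in this assay the printed step is still within the scatter (a number 8 percentage points lower from compound 3 to compound 4 (within the scatter)). Among these compounds, the new group also stays within the scatter of the two other groups at this aromatic carbon (a number 1 percentage points higher from compound 2 to compound 4 (within the scatter)) and (a number 1 percentage points higher from compound 1 to compound 4 (within the scatter)), so the position now holds four different groups, three of them five-membered aromatic rings with 2 hetero atoms, and no step among the four compounds lies beyond the scatter in this assay. Nothing measured here offers a reason for this, and no separate data on these groups are at hand.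

From the compounds shown here alone, whether a group of another kind on this carbon, such as an amine, a carboxylic acid or a longer alkyl chain, would give a step beyond the scatter remains open. Also open, going by these compounds, is whether replacing the trifluoromethyl groups of the shared core with chlorine or hydrogen would move the number in this assay, since all four compounds carry them unchanged.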